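Stretching the Ester Chain to a Heptadecyl Tail

The source may report more compounds than this note shows. Statements on the series, on what has been measured and on what is new or still open speak of the compounds shown alone.

Three esters sharing one core have been measured in a functional assay on A549 cells (Homo sapiens) for cytotoxicity, read by MTT assay, with a stated time of 24 h, tested at 40 uM; on this read-out higher numbers stand for a weaker effect at the one concentration tested and lower numbers for a stronger effect. Compound 1 `CCCCCCOC(=O)CCC(=O)N1CCN(CCCOc2cc3c(Nc4ccc(F)c(Cl)c4)ncnc3cc2OC)CC1` gives 74.2%. Compound 2 `CCCCCCCOC(=O)CCC(=O)N1CCN(CCCOc2cc3c(Nc4ccc(F)c(Cl)c4)ncnc3cc2OC)CC1` gives 59.1%. Compound 3 `CCCCCCCCCCCOC(=O)CCC(=O)N1CCN(CCCOc2cc3c(Nc4ccc(F)c(Cl)c4)ncnc3cc2OC)CC1` gives 12%, the lowest of the three, and so the strongest effect recorded here. Compound 4 `CCCCCCCCCCCCCCCCCOC(=O)CCC(=O)N1CCN(CCCOc2cc3c(Nc4ccc(F)c(Cl)c4)ncnc3cc2OC)CC1` carries the change (hexyl in place of hydrogen on a saturated chain carbon, ten or more bonds along the chain from an oxygen next to a carbonyl group). Among the measured compounds shown here, the steps that bear on it are a number 15.1 percentage points lower from compound 1 to compound 2 (beyond the scatter), a number 62.2 percentage points lower from compound 1 to compound 3 (beyond the scatter) and a number 47.1 percentage points lower from compound 2 to compound 3 (beyond the scatter), each a longer chain giving a lower number. The same direction is therefore expected for compound 4, though the read-out cannot fall far below compound 3, so the expected step of a number 5 percentage points lower from compound 3 to compound 4 (within the scatter) is small. Compound 4 is estimated at 7%, within 0% to 22%.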

Compound 4, a percentage reported as activity, at one concentration (the size of the read-out at that concentration, not a potency): 85.2%
Compound 4: the middle estimate sits 78.2 percentage points below what was measured; measured number outside the range, above it.
By their numbers in this assay, from the lowest: compound 3; then compound 2; then compound 1; then compound 4.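

In this assay a longer ester chain does not keep lowering the number: hexyl at this place reverses the direction, with a number 73.2 percentage points higher from compound 3 to compound 4 (beyond the scatter), and the long tail also ends up above both shorter esters, with a number 26.1 percentage points higher from compound 2 to compound 4 (beyond the scatter) and a number 11 percentage points higher from compound 1 to compound 4 (beyond the scatter). The fall across compound 1, compound 2 and compound 3 therefore holds only for those chains, and compound 4 goes against it. Nothing measured here accounts for the reversal.

Where the turn lies between compound 3 and compound 4 stays open. So does how a tetradecyl chain, or a chain ending in a carboxylic acid, would read at this place.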